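The source may hold more compounds than are shown below. What is called first, only, known or untested is meant among the compounds shown, and "the series" means these compounds.

Measured in a functional assay on A549 cells (Homo sapiens) for inhibition, read by MTT assay, with a stated time of 72 h; a higher number here means a weaker inhibitor, a lower number a stronger inhibitor:
Compound 1, `C/C=C\C(=O)Nc1cc(Nc2nc3c(c(-c4cn(C)c5ccc(F)cc45)n2)CSCC3)c(OC)cc1N(C)CCN(C)C`: 5310 nM.
Compound 2, `CC/C=C\C(=O)Nc1cc(Nc2nc3c(c(-c4cn(C)c5ccc(F)cc45)n2)CSCC3)c(OC)cc1N(C)CCN(C)C`: 1450 nM.
Compound 3, `C/C=C\C(=O)Nc1cc(Nc2nc3c(c(-c4cn(C)c5ccc(F)cc45)n2)CS(=O)(=O)CC3)c(OC)cc1N(C)CCN(C)C`: 3990 nM.

Compound 2 differs from compound 1 by methyl in place of hydrogen on a saturated chain carbon bound to a double-bonded chain carbon. This change brought a 3.7-fold lower number from compound 1 to compound 2 (0.56 log units; beyond the scatter), a modest gain. Compound 3 carries a different core; how its core differs from that of compound 1 is not broken down here, and in this assay compound 3 and compound 1 give values that lie within the usual scatter of each other.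

Compound 4, `CC/C=C\C(=O)Nc1cc(Nc2nc3c(c(-c4cn(C)c5ccc(F)cc45)n2)CS(=O)(=O)CC3)c(OC)cc1N(C)CCN(C)C`, is not yet measured. It differs from compound 3 by methyl in place of hydrogen on a saturated chain carbon bound to a double-bonded chain carbon, the same change at the same place as that between compound 1 and compound 2. Because a 3.7-fold lower number from compound 1 to compound 2 (0.56 log units; beyond the scatter) was found for this change on the related core, a step of similar size is expected here: a 3.6-fold lower number from compound 3 to compound 4 (0.56 log units; beyond the scatter). Among the compounds with values here, compound 4 is accordingly estimated at 1100 nM, with a likely range from 500 nM to 2500 nM; only one prior example supports this expectation.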

Compound 4, half-maximal inhibitory concentration: 5830 nM
For compound 4 the middle estimate is 5.3-fold (0.72 log units) below the measured one, outside the stated range (above it).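

In this assay the methyl in place of hydrogen on a saturated chain carbon bound to a double-bonded chain carbon gave a 1.5-fold higher number from compound 3 to compound 4 (0.16 log units; within the scatter), so the gain seen on the core of compound 1 did not carry over to the core of compound 3. The two steps do not agree: the same change on two cores in this assay, a 3.7-fold lower number (0.56 log units; beyond the scatter) from compound 1 to compound 2 and a 1.5-fold higher number (0.16 log units; within the scatter) from compound 3 to compound 4, 5.4-fold (0.73 log units) apart, beyond the scatter of two such steps. This shows that the change cannot be assumed to transfer from one core to the other in this series, but two pairs do not show what in the cores accounts for the difference, nor how the change would behave on a third core.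

The compounds shown leave open whether a longer chain in place of but-1-en-1-yl, or an amine on that chain, would follow the same course on both cores.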